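Removing the Acetyl Group from a Hexadecyl Amide

A few compounds are considered here, and "the series" means these few. Any claim that something is new, unique, unknown or untested is made for them only; others in the source may bear on it.

In a functional assay on cells (Homo sapiens) for antiproliferative activity, read by sulforhodamine B assay, with a stated time of 48 h (a higher number here means a weaker inhibitor, a lower number a stronger inhibitor), compound 1 `CCCCCCCCCCCCCCNC(=O)[C@@H]1CSC(c2ccc(NC(C)=O)cc2)N1` gives 2300 nM, compound 2 `CCCCCCCCCCCCCCCCNC(=O)[C@@H]1CSC(c2ccc(NC(C)=O)cc2)N1` gives 2100 nM and compound 3 `CCCCCCCCCCCCCCCCNC(=O)[C@H]1CSC(c2ccc(NC(C)=O)cc2)N1` gives 3200 nM. Compound 2 therefore stands within the scatter of both neighbours, and the three numbers do not separate. Going from the tetradecyl to the hexadecyl amide gives a 1.1-fold lower number from compound 1 to compound 2 (0.04 log units; within the scatter). Changing the stereocentre at a saturated ring carbon from R to S gives a 1.5-fold higher number from compound 2 to compound 3 (0.18 log units; within the scatter). Both steps are small, but neither touches the acetamido group, so they bear on the next change only indirectly.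

Compound 4 `CCCCCCCCCCCCCCCCNC(=O)[C@@H]1CSC(c2ccc(N)cc2)N1` differs from compound 2 in one place: hydrogen in place of acetyl on a nitrogen on an aromatic ring. This is hydrogen in place of acetyl on a nitrogen on an aromatic ring, so acetamido becomes amino and 4-acetamidophenyl becomes 4-aminophenyl. Among the measured compounds shown here, no measured compound varies this group, so the size of the change cannot be read directly from the series. For the measured compounds named here, the only guide is the reference value of compound 2, at 2100 nM, and no shift beyond the scatter is expected, though with a wide margin. The expected change is a 1.2-fold higher number from compound 2 to compound 4 (0.08 log units; within the scatter). Compound 4 is estimated at 2500 nM, with an expected range from 900 nM to 7000 nM.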

Compound 4, half-maximal inhibitory concentration: 2300 nM
Estimate against measurement, compound 4: 1.1-fold (0.04 log units) above; the range from low to high includes it.
By their numbers in this assay, from the lowest: compounds 2, 1, 4 and 3 (each within the scatter of the next).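

In this assay, taking the acetyl group off the nitrogen on the aromatic ring, so that 4-acetamidophenyl becomes 4-aminophenyl, gives a 1.1-fold higher number from compound 2 to compound 4 (0.04 log units; within the scatter). The earlier compounds shown here varied only the chain and the stereocentre, whereas this step varies the aromatic substituent itself and shows that, on the hexadecyl amide, the acetamido and amino forms do not separate in this read-out. Nothing in the information at hand bears on why this change leaves the two values within the scatter of each other.

The compounds shown leave open whether a larger acyl group such as benzoyl, a methanesulfonyl group or two methyl groups on this nitrogen would stay in the same range, and whether a hydroxyl or nitro group in place of the amino group would do so. They also leave open whether the same exchange of acetyl for hydrogen would hold on a tetradecyl or an octadecyl amide, or on the hexadecyl amide with the ring stereocentre drawn as in compound 3.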